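Swapping a sugar-side acetoxy for a triazolylsulfanyl group

The compounds below may be only part of what the source reports. "The series", "measured", "known", "first", "only" and "open" are said of these compounds alone.

Compound 1 `COc1cc(-c2nc(CO[C@@H]3O[C@H](CSc4ncn[nH]4)[C@H]4OC5(CCCC5)O[C@@H]34)no2)cc(OC)c1OC` gives 36000 nM in a functional assay on SW1573 cells (Homo sapiens) for antiproliferative activity, read by sulforhodamine B assay, with a stated time of 48 h; a lower number here means a stronger inhibitor of growth, a higher number a weaker inhibitor of growth.
Compound 2 `O=[N+]([O-])c1ccc(-c2nc(CO[C@@H]3O[C@H](CO)[C@H]4OC5(CCCC5)O[C@@H]34)no2)cc1` gives 27000 nM in this assay.
Compound 3 `CC(=O)OC[C@H]1O[C@@H](OCc2noc(-c3ccc([N+](=O)[O-])cc3)n2)[C@@H]2OC3(CCCC3)O[C@@H]21` gives 29000 nM in this assay.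

All three compounds share a core that carries an aromatic ring linked through an oxadiazole to a bicyclic sugar, and all three are weak growth inhibitors whose numbers lie within the scatter of one another. Compound 3 sits second highest of the three, nearest to compound 2 and furthest from compound 1, both gaps within the scatter.

Compound 4 `O=[N+]([O-])c1ccc(-c2nc(CO[C@@H]3O[C@H](CSc4ncn[nH]4)[C@H]4OC5(CCCC5)O[C@@H]34)no2)cc1` is compound 3 with one change: (1H-1,2,4-triazol-5-yl)sulfanyl in place of acetoxy on a saturated chain carbon bound to a saturated ring carbon. Among the compounds with values here, no measured step mirrors this exact change. Within the data shown here, the only measured step at the same position, a 1.1-fold higher number from compound 2 to compound 3 (0.03 log units; within the scatter), shows that exchanging one small oxygen-bound group for another there left the number essentially unchanged. Compound 1, which already carries the triazolylsulfanyl group but on a different aromatic ring, shows a number no further from compound 3 than the scatter allows. Together these points suggest no step beyond the scatter.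

Compound 4 is therefore expected to give 30000 nM in this assay, between 13000 nM and 65000 nM, meaning an estimated step of a 1.0-fold higher number from compound 3 to compound 4 (0.01 log units; within the scatter).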

Compound 4, concentration for 50% growth inhibition: 15000 nM
Compound 4: middle estimate off by 2.0-fold (0.30 log units), on the high side; measured number inside the range.
By their numbers in this assay, from the lowest: compounds 4, 2, 3 and 1 (each within the scatter of the next, the first and the last beyond it).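

In this assay, a group carrying a ring has now been compared directly with smaller oxygen-bound groups on a saturated chain carbon bound to a saturated ring carbon. Putting (1H-1,2,4-triazol-5-yl)sulfanyl in place of acetoxy gives one step (a 1.9-fold lower number from compound 3 to compound 4 (0.29 log units; within the scatter)), and putting it in place of hydroxy gives another (a 1.8-fold lower number from compound 2 to compound 4 (0.26 log units; within the scatter)), so among these three groups the change at this position stays within the scatter, even though the entering group has more heavy atoms and brings a hydrogen-bond donor that acetoxy lacks. Within the data shown here, with the triazolylsulfanyl group held constant, 4-nitrophenyl in place of 3,4,5-trimethoxyphenyl gives the only step here beyond the scatter, and a modest one (a 2.4-fold lower number from compound 1 to compound 4 (0.38 log units; beyond the scatter)), which points to the aromatic ring rather than the chain position as the place where a difference has been seen so far.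

Nothing measured here bears on why these numbers take the values they do. The compounds shown leave open how an amine or a carboxylic acid would behave on that chain carbon, and whether the same aromatic ring change gives a similar step when hydroxy or acetoxy sits there instead.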